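Amino in Place of Methylseleno on a Fused Core

A few compounds are considered here, and "the series" means these few. Any claim that something is new, unique, unknown or untested is made for them only; others in the source may bear on it.

In a functional assay on CCRF-CEM cells (Homo sapiens) for cytotoxicity, read by MTT assay, with a stated time of 72 h (on this read-out higher numbers stand for weaker inhibition of growth and lower numbers for stronger inhibition of growth), three compounds stand side by side. Compound 1 `CCCCC[Se]c1nc([Se]CCCCC)c2cccnc2n1` carries two pentylseleno groups on the shared core. Compound 1 reaches only > 100000 nM, which is a limit of the assay and not a number. Compound 3 `CSc1ccc(CNc2nc([SeH])nc3ccccc23)cc1` gives 71900 nM. For the measured compounds named here, compound 2 `C[Se]c1nc([Se]C)c2cccnc2n1` carries the same shared core as compound 1 with two methylseleno groups; for compound 2 the result is "not determined" (no result reported), so no number is reported, and the only other value on this core is the limit of > 100000 nM in this assay, at which 1 of the 3 values shown sits. Compound 4 `C[Se]c1nc(N)c2cccnc2n1` differs from compound 2 in one place: one nitrogen atom in place of a group of 2 heavy atoms (1 carbon, 1 selenium; no ring), on an aromatic carbon. No step between two measured compounds is shown, so the size and direction of the step from compound 2 to compound 4 in this assay cannot be read from the data; with compound 2 itself without a number, no movement beyond the scatter can be expected in either direction. Compound 3 shows 71900 nM, and nothing on the shared core of compound 2 reaches a number, so compound 4 is expected to remain weak. Compound 4 is estimated at 90000 nM, with a range from 20000 nM to 300000 nM, and a limit rather than a number is thought likely.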

Compound 4, concentration for 50% growth inhibition: 68400 nM
Compound 4: the middle estimate sits 1.3-fold (0.12 log units) above what was measured, and the stated range covers the measured number.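

No step can be read from compound 2 to compound 4: in this assay compound 2 has no reported result, while compound 4 gives 68400 nM. The compounds shown leave open whether amino in place of methylseleno changes growth inhibition on the shared core at all, as compound 1 offers only a limit there: the limit of > 100000 nM in this assay, at which 1 of the 4 values shown sits.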